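Swapping phenyl for (furan-3-yl)methyl in compound 2

This account rests on a few compounds, and the source may have more. Where it says the series, first, only, none or still open, it means among the compounds named here.

In a functional assay on the whole organism with Mus musculus as the target (on this read-out lower numbers stand for an effect already at smaller amounts and higher numbers for an effect only at larger amounts of compound), compound 2 (`C[C@@H](NCc1ccc(Oc2ccccc2)cc1)C(N)=O`) gives 64 mg/kg as its dose. Compound 1 (`CC[C@H](NCc1ccc(OCc2ccccc2)cc1)C(N)=O`) gives 119 mg/kg on the same read-out, and these two values lie within the usual scatter of each other, so they cannot be told apart. Compound 3 (`C[C@@H](NCc1ccc(Cc2ccccc2)cc1)C(N)=O`) gives 15.7 mg/kg as its dose, a number clearly lower than that of compound 2.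

The next compound, compound 4 (`C[C@@H](NCc1ccc(OCc2ccoc2)cc1)C(N)=O`), carries (furan-3-yl)methyl in place of phenyl on an oxygen on an aromatic ring. A five-membered aromatic ring with 1 hetero atom thus enters where a six-membered aromatic ring of carbon only leaves.

Going by the values given here, no measured pair differs in this one place alone, so the expectation leans only on the spread from compound 3 at 15.7 mg/kg to compound 1 at 119 mg/kg in this assay. A modest step (a 1.6-fold lower number from compound 2 to compound 4 (0.20 log units; within the scatter)) is expected, toward a lower number and not beyond the scatter. For compound 4 the estimate is 40 mg/kg as a middle value, with an expected range from 13 mg/kg to 120 mg/kg around it.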

Compound 4, dose for half-maximal effect: 152 mg/kg
Compound 4: middle estimate off by 3.8-fold (0.58 log units), on the low side; measured number above the stated range.
By their numbers in this assay, from the lowest: compound 3; then compounds 2, 1 and 4 (each within the scatter of the next, the first and the last beyond it).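

In this assay, going by these compounds alone, this is the first change measured at this one place alone: putting (furan-3-yl)methyl in place of phenyl on the oxygen gives a 2.4-fold higher number from compound 2 to compound 4 (0.38 log units; beyond the scatter), so more compound is needed for the effect, and the group held on this oxygen does matter. The swap alters two things at once, since a five-membered aromatic ring with a hetero atom replaces a six-membered aromatic ring of carbon only, and the ring now sits on a methyl link. Nothing measured here gives a reason for the rise.

The compounds shown do not separate the effect of the new ring from that of the methyl link. A thiophene or pyridine ring on the same methyl link could help to show which part counts.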